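The source may report more compounds than this note shows. Statements on the series, on what has been measured and on what is new or still open speak of the compounds shown alone.

Measured compounds in an assay on cells for inhibition of HSP60/HSP10 (Homo sapiens), with a stated time of 60 min; on this read-out higher numbers stand for weaker inhibition and lower numbers for stronger inhibition:
compound 1 `Cc1ccccc1S(=O)(=O)Nc1ccc2oc(-c3ccccc3)nc2c1` gives > 100000 nM, a limit of the assay.
compound 2 `CS(=O)(=O)Nc1ccc(-c2nc3ccccc3o2)cc1` gives > 100000 nM, a limit of the assay.
compound 3 `O=S(=O)(Nc1ccc(-c2nc3ccccc3o2)cc1)c1ccccc1F` gives > 100000 nM, a limit of the assay.

Compound 1 stands only at a limit in this assay, and the two further values shown are limits as well, so no order among the three compounds can be read. For the measured compounds named here, the single step between measured compounds that differ in one place, a step that the two limits leave unreadable from compound 2 to compound 3, is one the two limits leave unreadable; its size is not known. What the three measured values have in common is the limit of > 100000 nM in this assay, at which 3 of the 3 values shown sit.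

Compound 4 `O=S(=O)(Nc1ccc2oc(-c3ccccc3)nc2c1)c1ccccc1Cl` differs from compound 1 by chloro in place of methyl on an aromatic carbon. Going by the values given here, the one measured step that bears on a change of the group on the sulfonyl sulfur, 2-fluorophenyl in place of methyl, yields no size, since both of its ends sit at the limit. Among the compounds with values here, no measured step therefore supports an expectation of a move beyond the scatter in this assay in either direction. The step of a number no higher from compound 1 to compound 4 (the limit leaves the size open) is expected to be none beyond the scatter. The estimate for compound 4 is 100000 nM, within 30000 nM to 300000 nM, most likely reported again only as a limit.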

Compound 4, half-maximal inhibitory concentration: > 100000 nM
Compound 4: no number, only a limit; the forecaster's own chance of this, stated with the estimate: 80%; the middle value sits exactly at the limit.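

No step can be read from compound 1 to compound 4, chloro in place of methyl on an aromatic carbon, because both ends sit at one limit: the limit of > 100000 nM in this assay, at which 4 of the 4 values shown sit.

The compounds shown leave open what change to the shared core would give a number in this assay.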